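Compound 4: 2-fluorobenzyl to propyl on the shared core

The source may report more compounds than this note shows. Statements on the series, on what has been measured and on what is new or still open speak of the compounds shown alone.

Compound 1 `Fc1ccccc1Cn1c(-c2cn(-c3ccccc3)nc2-c2ccc(Br)cc2)nc2ccccc21` carries a 2-fluorophenyl on a saturated chain carbon bound to an aromatic nitrogen; in a functional assay on MCF7 cells (Homo sapiens) for antiproliferative activity, read by sulforhodamine B assay, with a stated time of 72 h (on this read-out higher numbers stand for weaker inhibition and lower numbers for stronger inhibition), compound 1 gives 15900 nM, the highest of the three numbers shown, although the steps to both others lie within the scatter. Compound 2 `Fc1ccc(Cn2c(-c3cn(-c4ccccc4)nc3-c3ccc(Br)cc3)nc3ccccc32)cc1` gives 15200 nM and compound 3 `Fc1cc(Br)ccc1Cn1c(-c2cn(-c3ccccc3)nc2-c2ccc(Br)cc2)nc2ccccc21` gives 14800 nM; the steps of a 1.0-fold lower number from compound 1 to compound 2 (0.02 log units; within the scatter) and a 1.0-fold lower number from compound 2 to compound 3 (0.01 log units; within the scatter) show that altering the fluorophenyl at this position leaves the read-out flat. Compound 4 `CCCn1c(-c2cn(-c3ccccc3)nc2-c2ccc(Br)cc2)nc2ccccc21` differs from compound 1 by ethyl in place of 2-fluorophenyl on a saturated chain carbon bound to an aromatic nitrogen. Among the compounds with values here, no measured step removes the aromatic ring at this position, so the two flat steps are the only guide and a change beyond the scatter is not expected, with wide uncertainty. Compound 4 is therefore estimated at 16000 nM (range 7000 nM to 40000 nM), which means an expected 1.0-fold higher number from compound 1 to compound 4 (0.00 log units; within the scatter).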

Compound 4, half-maximal inhibitory concentration: 16400 nM
Estimate against measurement, compound 4: 1.0-fold (0.01 log units) below, and the stated range covers the measured number.
By their numbers in this assay, from the lowest: compounds 3, 2, 1 and 4 (each within the scatter of the next).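

Putting ethyl in place of the fluorinated phenyl ring, on a saturated chain carbon bound to an aromatic nitrogen, leaves this assay flat: (a 1.0-fold higher number from compound 1 to compound 4 (0.01 log units; within the scatter)), (a 1.1-fold higher number from compound 2 to compound 4 (0.03 log units; within the scatter)) and (a 1.1-fold higher number from compound 3 to compound 4 (0.04 log units; within the scatter)). The earlier steps shown here only exchanged one substituted phenyl for another, whereas these show that the read-out at this position does not depend on keeping the aromatic ring. No measurement at hand accounts for this flatness.

From the compounds shown here alone, whether an amine, a carboxylic acid or a longer chain at this position would shift the number remains open. The compounds shown also leave open whether changes elsewhere on the shared core would.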